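This account rests on a few compounds, and the source may have more. Where it says the series, first, only, none or still open, it means among the compounds named here.

Compound 1 `CC1=CC[C@@H]([C@@](C)(O)CCCC(C)(C)NC(=S)NN)CC1` gives 12800 nM
Compound 2 `CC1=CC[C@@H]([C@@](C)(O)CCCC(C)(C)NC(=S)N/N=C\c2ccc(N(C)C)cc2)CC1` gives 19600 nM

Among the compounds with values here, both values come from a functional assay on NCI-H460 cells (Homo sapiens) for cytotoxicity, read by sulforhodamine B assay (a higher number here means a weaker inhibitor of growth, a lower number a stronger inhibitor of growth), and they are the only measurements available for this series. Compound 2 stands within the usual scatter of compound 1, so the two cannot be ranked against each other.

Compound 3 `CC1=CC[C@@H]([C@@](C)(O)CCCC(C)(C)NC(=S)N/N=C\c2cccc(Cl)c2)CC1` keeps the shared core of compound 2 and carries 3-chlorophenyl in place of 4-(dimethylamino)phenyl on a carbon with a double bond to nitrogen. The count of that exchange reads (3-chlorophenyl in place of 4-(dimethylamino)phenyl on a carbon with a double bond to nitrogen). Within the data shown here, no measured pair of compounds shows what such an exchange does, so the size of the step has to be judged from very little. The two values at hand, compound 1 at 12800 nM and compound 2 at 19600 nM, sit close together, and that gives no ground for expecting a large move. The expected change is a 1.4-fold lower number from compound 2 to compound 3 (0.15 log units; within the scatter), which is an estimate of a small shift towards a lower number and no step beyond the scatter. For compound 3 the expected value is 14000 nM, with an estimated range from 5000 nM to 40000 nM.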

Compound 3, concentration for 50% growth inhibition: 44300 nM
Compound 3: middle estimate off by 3.2-fold (0.50 log units), on the low side; measured number outside the range, above it.
By their numbers in this assay, from the lowest: compounds 1 and 2 (each within the scatter of the next); then compound 3.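

In this assay, the group on the carbon with a double bond to nitrogen now proves able to shift the number: 3-chlorophenyl in place of 4-(dimethylamino)phenyl gives a 2.3-fold higher number from compound 2 to compound 3 (0.35 log units; beyond the scatter), whereas compound 1 and compound 2 could not be ranked against each other. The same holds against the shared core without an aromatic ring at this end, where the group carrying 3-chlorophenyl in place of one nitrogen atom on the amide-type nitrogen gives a 3.5-fold higher number from compound 1 to compound 3 (0.54 log units; beyond the scatter). Adding an aromatic ring here therefore does not have one fixed result: with 4-(dimethylamino)phenyl the number stays within the scatter of compound 1, while with 3-chlorophenyl it moves towards weaker inhibition of growth, although this rests on a single exchange.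

The compounds shown cannot separate the effect of gaining the chlorine from that of losing the dimethylamino group, which a plain phenyl, a methoxy group or a bromine would help to resolve. From the compounds shown here alone, whether any group on this ring, such as a carboxylic acid or a primary amine, could bring the number below that of compound 1 also stays open. Nothing measured here explains the rise in the number.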